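A few compounds are considered here, and "the series" means these few. Any claim that something is new, unique, unknown or untested is made for them only; others in the source may bear on it.

Compound 1 `C=C[C@@H]1C[C@]1(NC(=O)[C@@H]1C[C@@H](Oc2cc(-c3ccccc3)nc3cc(OC)ccc23)CN1C(=O)[C@@H](NC(=O)NC(C)(C)C)C(C)(C)C)C(=O)NS(=O)(=O)C1CC1` gives 17 ng.h/mL in an ADME assay on the whole organism (plasma, Rattus norvegicus, strain Sprague-Dawley) for pharmacokinetics, read by LC-MS, with a stated time of 4 h, at a dose of 15 mg/kg by the intraduodenal route; on this read-out lower numbers stand for lower exposure and higher numbers for higher exposure at the dose given. Among the compounds with values here, compound 2 `C=C[C@@H]1C[C@]1(NC(=O)[C@@H]1C[C@@H](Oc2cc(-c3ccccc3)nc3cc(OC)ccc23)CN1C(=O)[C@@H](NC(=O)N(C)C(C)(C)C)C(C)(C)C)C(=O)NS(=O)(=O)C1CC1` gives 32 ng.h/mL in this assay, and the single measured step, a 1.9-fold higher number from compound 1 to compound 2 (0.27 log units; within the scatter), leaves compound 2 and compound 1 within the scatter of each other, so neither stands apart. Compound 3 `C=C[C@@H]1C[C@]1(NC(=O)[C@@H]1C[C@@H](Oc2cc(-c3ccccc3)nc3cc(OC)ccc23)CN1C(=O)[C@@H](OC(=O)NC1CCCC1)C(C)(C)C)C(=O)NS(=O)(=O)C1CC1` differs from compound 2 by (cyclopentylcarbamoyl)oxy in place of (methyl(tert-butyl)carbamoyl)amino on a saturated chain carbon bound to a carbonyl carbon and a saturated chain carbon. Within the data shown here, no measured step bears on this change, and the one step known stayed within the scatter. Compound 3 is therefore expected to give about 30 ng.h/mL in this assay, with a wide range from 8 ng.h/mL to 120 ng.h/mL. The expected step is a 1.1-fold lower number from compound 2 to compound 3 (0.03 log units; within the scatter), with no direction beyond the scatter.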

Compound 3, area under the concentration-time curve: 95 ng.h/mL
Compound 3: the middle estimate sits 3.2-fold (0.50 log units) below what was measured, within the range that was stated.
By their numbers in this assay, from the lowest: compounds 1 and 2 (each within the scatter of the next); then compound 3.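

At this place on a saturated chain carbon bound to a carbonyl carbon and a saturated chain carbon, exchanging the whole group moves the number in this assay beyond the scatter, which the methyl step did not do. The (cyclopentylcarbamoyl)oxy group gives a 3.0-fold higher number from compound 2 to compound 3 (0.47 log units; beyond the scatter) and a 5.6-fold higher number from compound 1 to compound 3 (0.75 log units; beyond the scatter) as well, so both urea-bearing compounds lie lower. No evidence on hand accounts for this rise.

Because the link and the ring change together, the compounds shown leave open which of them carries the step. A (tert-butylcarbamoyl)oxy group would separate the two, and a cyclohexyl ring would test the ring size.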